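The compounds below may be only part of what the source reports. "The series", "measured", "known", "first", "only" and "open" are said of these compounds alone.

Compound 1 `Cc1cn(C2CCN(Cc3ccnc(Oc4cccc(Cl)c4)c3)CC2)c(=O)[nH]c1=O` was tested in an ADME assay on MRC5 cells (Homo sapiens) for cytotoxicity, read by fluorescence and resazurin assay, with a stated time of 3 days (on this read-out lower numbers stand for stronger inhibition and higher numbers for weaker inhibition), where it gives only a limit of the assay, > 64000 nM, and not a number. Compound 2 `Cc1cn(C2CCN(Cc3cccc(Oc4cccnc4)c3)CC2)c(=O)[nH]c1=O` likewise reaches only a limit in this assay, > 64000 nM. Among the compounds with values here, compound 1 therefore stands at the same limit as the one other value shown, because of the limit of > 64000 nM in this assay, at which 2 of the 2 values shown sit. Compound 3 `Cc1cn(C2CCN(Cc3ccnc(Oc4ccccc4)c3)CC2)c(=O)[nH]c1=O` differs from compound 1 in one place: hydrogen in place of chloro on an aromatic carbon. Within the data shown here, no measured step of this kind is available, so in this assay no change beyond the usual scatter is expected, and compound 3 is expected to sit again at the limit. The estimate for compound 3 is 100000 nM, within 64000 nM to 300000 nM. The expected step is a step that the limit leaves unreadable from compound 1 to compound 3.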

Compound 3, half-maximal inhibitory concentration: > 64000 nM
Compound 3: a limit, no number (the forecaster's own chance of this, stated with the estimate: 90%); the middle value lies beyond the limit too.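

Within the data shown here, compound 1 and compound 3 each give only a limit of the assay, not a number, so no step between them can be read. The compounds shown leave open where their true values lie and whether hydrogen in place of chloro changes anything.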